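The source may hold more compounds than are shown below. What is called first, only, known or untested is meant among the compounds shown, and "the series" means these compounds.

In a functional assay on KB cells (Homo sapiens) for inhibition, read by MTT assay, with a stated time of 24 h, tested at 0.1 ug/mL (on this read-out higher numbers stand for more inhibition of growth at the one concentration tested and lower numbers for less inhibition of growth), the results so far are these
compound 1 `O=C(CCCCC1CCSS1)NO` gives 7.92%
compound 2 `O=C(CCCCC(S)CCS)NO` gives 7.62%
compound 3 `O=C(CCCCC1CCSS1)Nc1ccccn1` gives "not active" (no number reported)

Compound 3 has no number on this scale. It is reported only as "not active" (no number reported) without any figure attached, so a comparison with it can only be loose.

The next compound to consider is compound 4 `O=C(CCCCC(S)CCS)Nc1ccccn1`, which is reached by one structural change. The change is a group of 5 heavy atoms (3 carbon, 2 sulfur; no ring) in place of a group of 5 heavy atoms (3 carbon, 2 sulfur; one five-membered non-aromatic ring with 2 hetero atoms), on a saturated chain carbon, four bonds along the chain from a carbonyl carbon and it takes place on a saturated chain carbon, four bonds along the chain from a carbonyl carbon. The group that enters is 1,3-disulfanylpropyl, which has no ring.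

For the measured compounds named here, no measured step shows this change directly. The closest evidence is compound 1 at 7.92% and compound 2 at 7.62%, two values within the usual scatter of each other. In this assay no step beyond the scatter is therefore expected, in either direction.

Compound 4 is estimated at 5%, with an expected range from 0% to 15%.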

Compound 4, percent growth inhibition at one concentration: "not active" (no number reported)
For compound 4 the study gives words and no number, and the estimate cannot be compared.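

In this assay compound 3 gives "not active" (no number reported) and compound 4 gives "not active" (no number reported), so no step can be read between them. As far as these compounds go, whether the entry of 1,3-disulfanylpropyl alters growth inhibition here stays open. Nothing shown offers an explanation for these results.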